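Dimethoxy Substitution on the Benzyl Ester of Compound 3

A few compounds are considered here, and "the series" means these few. Any claim that something is new, unique, unknown or untested is made for them only; others in the source may bear on it.

Compound 3 `COC(=O)C1=C(C)NC(C)=C(C(=O)OCc2ccccc2)C1c1cccc([N+](=O)[O-])c1` gives 25 nM in a functional assay on HEK293 cells for antagonist activity at Voltage-dependent L-type calcium channel subunit alpha-1C (Oryctolagus cuniculus), read by FLIPR; a higher number here means a weaker inhibitor, a lower number a stronger inhibitor. Among the three measured compounds it stands second highest, nearest to compound 2 `C=C(C)CCOC(=O)C1=C(C)NC(C)=C(C(=O)OC)C1c1cccc([N+](=O)[O-])c1` with 23 nM and furthest from compound 1 `C#CCCOC(=O)C1=C(C)NC(C)=C(C(=O)OC)C1c1cccc([N+](=O)[O-])c1` with 31 nM, and both steps, a 1.2-fold lower number from compound 1 to compound 3 (0.09 log units; within the scatter) and a 1.1-fold higher number from compound 2 to compound 3 (0.04 log units; within the scatter), lie within the scatter. Compound 4 `COC(=O)C1=C(C)NC(C)=C(C(=O)OCc2ccc(OC)c(OC)c2)C1c1cccc([N+](=O)[O-])c1` differs from compound 3 by 3,4-dimethoxyphenyl in place of phenyl on a saturated chain carbon bound to an oxygen next to a carbonyl group. Within the data shown here, the only measured steps touching this saturated chain carbon are those two, both small, and none tells how a substituent on the ring there behaves. The expected step in this assay is therefore no change at the digits printed from compound 3 to compound 4 (within the scatter), nothing beyond the scatter. Compound 4 is estimated at 25 nM, within a range from 9 nM to 70 nM.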

Compound 4, half-maximal inhibitory concentration: 112 nM
The estimate for compound 4 lay 4.5-fold (0.65 log units) below the measured number; measured number above the stated range.
By their numbers in this assay, from the lowest: compounds 2, 3 and 1 (each within the scatter of the next); then compound 4.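

Among these compounds, the 3,4-dimethoxybenzyl ester is the first change at this saturated chain carbon to go beyond the scatter, with a 4.5-fold higher number from compound 3 to compound 4 (0.65 log units; beyond the scatter), whereas the earlier ester groups all stayed within the scatter of one another. The other two steps, a 4.9-fold higher number from compound 2 to compound 4 (0.69 log units; beyond the scatter) and a 3.6-fold higher number from compound 1 to compound 4 (0.56 log units; beyond the scatter), show that compound 4 is the weakest inhibitor of the four. Nothing available explains this result. The compounds shown leave open whether a single methoxy group on the benzyl ring would give a similar step. They also leave open how a fluorine, hydroxyl or amine on that ring would read.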